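From bromo to methoxy: what to expect for compound 3

The source may hold more compounds than are shown below. What is called first, only, known or untested is meant among the compounds shown, and "the series" means these compounds.

Compound 1 `COc1ccc(/C=C/C(=O)c2ccccc2Br)c(OC)c1`: 35000 nM
Compound 2 `COc1ccc(/C=C/C(=O)c2cccc(Br)c2)c(OC)c1`: 37000 nM

In a functional assay (Homo sapiens) for inhibition (a higher number here means a weaker inhibitor, a lower number a stronger inhibitor), compound 1 gives 35000 nM and compound 2 gives 37000 nM. These two numbers lie within the scatter of each other, so compound 1 has no clear rank among the measured compounds.

Compound 3 `COc1ccc(/C=C/C(=O)c2ccccc2OC)c(OC)c1` keeps the core of compound 1 and differs from it by one change: methoxy in place of bromo on an aromatic carbon. In words, this is methoxy in place of bromo on an aromatic carbon, ortho to a large group.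

Among the compounds with values here, only one measured step bears on this: a 1.1-fold higher number from compound 1 to compound 2 (0.02 log units; within the scatter). That step moved the bromo group rather than replacing it, so it offers indirect guidance at best. Within the data shown here, no measured step replaces bromo with another group.

In this assay, the expected result is a 1.1-fold higher number from compound 1 to compound 3 (0.06 log units; within the scatter), with no change beyond the scatter and no firm direction. Compound 3 is estimated at 40000 nM, with an expected range of 13000 nM to 100000 nM.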

Compound 3, half-maximal inhibitory concentration: 26000 nM
The estimate for compound 3 lay 1.5-fold (0.19 log units) above the measured number; measured number inside the range.
By their numbers in this assay, from the lowest: compounds 3, 1 and 2 (each within the scatter of the next).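

In this assay, the first direct replacement of the bromo group gives a 1.3-fold lower number from compound 1 to compound 3 (0.13 log units; within the scatter), so compounds 1 and 3 cannot be told apart. The earlier compounds shown here showed only that moving bromo around the ring left the number within the scatter; this result adds that bromo itself, on an aromatic carbon ortho to a large group, can give way to methoxy with the same outcome. That exchange goes from one heavy atom to two and brings in one hydrogen-bond acceptor, yet no difference beyond the scatter appears. No available measurement offers an explanation for this result.

From the compounds shown here alone, whether an amine or a carboxylic acid at this place would shift the number beyond the scatter remains open. So does whether a hydroxy group or a longer alkoxy chain would do so.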